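The source may hold more compounds than are shown below. What is called first, only, known or untested is meant among the compounds shown, and "the series" means these compounds.

Working notes on the series. Compound 2 `CCCCCCCCc1cn(C/C=C(\C)CC/C=C(\C)CCC=C(C)C)nn1` gives 8.76 in a physicochemical assay for lipophilicity, measured as octanol-water partition (a lower number here means a more polar compound, a higher number a more lipophilic compound), and compound 1 `CCCc1cn(C/C=C(\C)CC/C=C(\C)CCC=C(C)C)nn1` gives 6.5 in this assay. The two differ by one change, (hydrogen in place of pentyl on a saturated chain carbon, three bonds along the chain from an aromatic carbon), which made the step of a number 2.26 log units lower from compound 2 to compound 1 (beyond the scatter). Going by the values given here, compound 3 `CCCCCCCCc1cn(CC=C(C)C)nn1` gives 4.92 in this assay, the lowest of the three numbers measured so far; the difference between the core of compound 3 and the core of compound 2 is not broken down here. Compound 4 `CCCc1cn(CC=C(C)C)nn1` is not yet measured and differs from compound 3 by hydrogen in place of pentyl on a saturated chain carbon, three bonds along the chain from an aromatic carbon, the same change that separates compound 2 from compound 1, at the same place. The step from compound 3 to compound 4 in this assay is expected to be a number 2.26 log units lower from compound 3 to compound 4 (beyond the scatter), resting on the earlier step of a number 2.26 log units lower from compound 2 to compound 1 (beyond the scatter). Compound 4 is therefore estimated at 2.66 in this assay, expected to fall between 2.2 and 3.1.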

Compound 4, partition coefficient: 2.47
For compound 4 the middle estimate is 0.19 log units above the measured one, and the stated range covers the measured number.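

In this assay, the change from pentyl to hydrogen gives a number 2.45 log units lower from compound 3 to compound 4 (beyond the scatter) on one core and a number 2.26 log units lower from compound 2 to compound 1 (beyond the scatter) on the other, so the two steps run in the same direction and each lies beyond the scatter. The change therefore carries over between the core of compound 2 and the core of compound 3, the only two cores shown. This does not show that it would carry to any further core, and no evidence bears on what sets the size of either step.

Going by these compounds, it remains open whether a longer chain such as decyl gives a step of similar size on either core. On these data alone, it is also open how an amine or a carboxylic acid in place of pentyl would read in this assay.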